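This account rests on a few compounds, and the source may have more. Where it says the series, first, only, none or still open, it means among the compounds named here.

In a functional assay on S1 cells (Homo sapiens) for cytotoxicity, read by MTT assay, with a stated time of 72 h (on this read-out lower numbers stand for stronger inhibition and higher numbers for weaker inhibition), compound 1 (`COc1ccc(/C=C/C(=O)CC(C)=O)cc1OC`) gives 9300 nM and compound 2 (`COc1ccc(/C=C/C(=O)CC(C)=O)cc1`) gives 44600 nM, so compound 2 holds the higher of the two numbers and is the weaker of the pair. Compound 3 (`CC(=O)CC(=O)/C=C/c1ccc(O)cc1`) has not yet been measured. It differs from compound 2 by hydrogen in place of methyl on an oxygen on an aromatic ring, or methoxy to hydroxy.

Among the measured compounds shown here, only one measured step bears on this change, and only indirectly: a 4.8-fold higher number from compound 1 to compound 2 (0.68 log units; beyond the scatter), a modest step with hydrogen in place of methoxy on an aromatic carbon. For the measured compounds named here, no measured pair shows the exchange of methyl for hydrogen on that oxygen, so the direction is poorly defined. A step no larger than the modest one seen is expected, with a slight lean towards a lower number, given that compound 2 stands at 44600 nM, the top of the measured values. The estimated change is a 1.5-fold lower number from compound 2 to compound 3 (0.17 log units; within the scatter), which may not clear the usual scatter. Compound 3 is expected at 30000 nM, with an estimated range of 12000 nM to 75000 nM.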

Compound 3, half-maximal inhibitory concentration: 10600 nM
Beside the measured number, compound 3's estimate is 2.8-fold (0.45 log units) above it, outside the stated range (below it).
By their numbers in this assay, from the lowest: compounds 1 and 3 (each within the scatter of the next); then compound 2.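

In this assay the exchange on the oxygen on the aromatic ring gives a 4.2-fold lower number from compound 2 to compound 3 (0.62 log units; beyond the scatter) and so lies beyond the scatter, which makes this oxygen a place where a single change of one methyl for hydrogen moves the number. Compound 2 had until now been read only against compound 1 through a 4.8-fold higher number from compound 1 to compound 2 (0.68 log units; beyond the scatter), a change at a different aromatic carbon, so the earlier pair said nothing about the methyl on this oxygen. Both steps are modest, and each runs towards a lower number for the compound that carries something other than the plain compound 2 arrangement, though two steps are too few to call this a pattern; nothing in the data available explains the size or direction of the new step.

Open is how far this place tolerates other groups, since only methyl and hydrogen on the oxygen are shown, leaving an ethyl or longer chain on that oxygen, or an amine or a fluorine in its stead, without a reading. Also open, on these data alone, is whether the same exchange of methyl for hydrogen carries over to the core of compound 1, where a second methoxy is present.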